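The compounds below may be only part of what the source reports. "The series", "measured", "known", "first", "only" and "open" are said of these compounds alone.

Measured so far in an ADME assay on HepG2 cells (Homo sapiens) for cytotoxicity; on this read-out higher numbers stand for lower toxicity in this test and lower numbers for higher toxicity in this test:
- compound 1 `CSc1cccc(N2C(=O)CN(c3ccccc3)CC2C(=O)NC2CCCC2)c1`: > 50000 nM
- compound 2 `O=C(NCC1CC1)C1CN(c2ccccc2)CC(=O)N1c1ccc2ccsc2c1`: > 50000 nM

Both entries are limits of the read-out and not numbers, and they sit together: the limit of > 50000 nM in this assay, at which 2 of the 2 values shown sit. No value in the series therefore gives a graded reading of cytotoxicity.

Compound 2 stands at > 50000 nM, which is a limit only.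

Compound 3 `O=C(NC1CCCC1)C1CN(c2ccccc2)CC(=O)N1c1ccc2ccsc2c1` has not yet been measured. It keeps the rest of compound 2 and differs in one place: cyclopentyl in place of cyclopropylmethyl on an amide-type nitrogen. In words, cyclopentyl takes the place of cyclopropylmethyl on an amide-type nitrogen.

Among the compounds with values here, no step between measured compounds is available to size this kind of change. In this assay no shift beyond the scatter is expected, because compound 2 gives > 50000 nM and nothing measured points to a drop in the half-maximal cytotoxic concentration. The expected step of a number no higher from compound 2 to compound 3 (the limit leaves the size open) is small, and a second reading at the limit is the likeliest outcome.

The estimate for compound 3 is 50000 nM, with an expected range of 25000 nM to 100000 nM.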

Compound 3, half-maximal cytotoxic concentration: > 50000 nM
Compound 3: a limit, no number; the forecaster's own chance of this, stated with the estimate: 80%; the middle value lies on the limit itself.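

Compound 3 gives a limit and no number in this assay, as do compound 1 and compound 2, so neither the step from compound 2 to compound 3 nor the step from compound 1 to compound 3 can be read: the limit of > 50000 nM in this assay, at which 3 of the 3 values shown sit.

The compounds shown leave open whether either exchange, cyclopentyl for cyclopropylmethyl or 1-benzothiophen-6-yl for 3-(methylsulfanyl)phenyl, changes the half-maximal cytotoxic concentration at all.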